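N-aryl substituent scan on the shared core

A few compounds are considered here, and "the series" means these few. Any claim that something is new, unique, unknown or untested is made for them only; others in the source may bear on it.

Measured so far in a functional assay on MKN-45 cells (Homo sapiens) for cytotoxicity, read by MTT assay, with a stated time of 72 h; on this read-out higher numbers stand for weaker inhibition and lower numbers for stronger inhibition:
compound 1 `COc1cc2c(Oc3ccc(NC(=O)c4nn(-c5ccccc5)c(=O)c5ccccc45)cc3F)ccnc2cc1OCCCN1CCC(C)CC1` gives 580 nM
compound 2 `COc1cc2c(Oc3ccc(NC(=O)c4nn(-c5cccc(F)c5)c(=O)c5ccccc45)cc3F)ccnc2cc1OCCCN1CCC(C)CC1` gives 220 nM
compound 3 `COc1cc2c(Oc3ccc(NC(=O)c4nn(-c5ccccc5F)c(=O)c5ccccc45)cc3F)ccnc2cc1OCCCN1CCC(C)CC1` gives 260 nM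

Compound 3 holds the second highest of the three numbers. Its nearest neighbour is compound 2, the step of a 1.2-fold higher number from compound 2 to compound 3 (0.07 log units; within the scatter) lying within the scatter, so no order between the two is claimed. The furthest is compound 1, the step of a 2.2-fold lower number from compound 1 to compound 3 (0.35 log units; beyond the scatter) being modest but beyond the scatter.

The next compound, compound 4 `COc1cc2c(Oc3ccc(NC(=O)c4nn(-c5ccc([N+](=O)[O-])cc5)c(=O)c5ccccc45)cc3F)ccnc2cc1OCCCN1CCC(C)CC1`, differs from compound 3 in one place: 4-nitrophenyl in place of 2-fluorophenyl on an aromatic nitrogen.

The measured steps that bear on this position are a 2.6-fold lower number from compound 1 to compound 2 (0.42 log units; beyond the scatter) and a 2.2-fold lower number from compound 1 to compound 3 (0.35 log units; beyond the scatter), both fluoro in place of hydrogen on the phenyl that sits on the ring nitrogen, both modest and in the same direction, while moving the fluoro between two positions gave a 1.2-fold higher number from compound 2 to compound 3 (0.07 log units; within the scatter). Going by the values given here, no step with a nitro group, and none at the fourth position of this phenyl, has been measured. Substitution on this phenyl has so far produced only modest movement, and the expectation for compound 4 is therefore a step of about a 1.5-fold higher number from compound 3 to compound 4 (0.19 log units; within the scatter) in this assay, with the number estimated at 400 nM, within 130 nM to 1200 nM.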

Compound 4, half-maximal inhibitory concentration: 1150 nM
The estimate for compound 4 lay 2.9-fold (0.46 log units) below the measured number; the measured number falls inside the stated range.
By their numbers in this assay, from the lowest: compounds 2 and 3 (each within the scatter of the next); then compounds 1 and 4 (each within the scatter of the next).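

In this assay, going by these compounds alone, 4-nitrophenyl on the aromatic nitrogen gives the first upward steps at this position, with a 4.4-fold higher number from compound 3 to compound 4 (0.65 log units; beyond the scatter) and a 5.2-fold higher number from compound 2 to compound 4 (0.72 log units; beyond the scatter) both beyond the scatter, so the lower numbers seen with the two fluorophenyl groups do not extend to every substituted phenyl here. Set against the unsubstituted phenyl, nitro in place of hydrogen gives a 2.0-fold higher number from compound 1 to compound 4 (0.30 log units; within the scatter) and no order between these two compounds is claimed, which leaves fluoro as the only substituent here with a step to lower numbers beyond the scatter. Nothing in the available data accounts for this difference between the fluoro and nitro groups.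

Open, on these data alone, is whether the rise belongs to the nitro group or to its place on the phenyl: a 4-fluorophenyl or a 3-nitrophenyl would separate the two. As far as these compounds go, how an amine or a methoxy group on this phenyl would compare also stays open.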